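Swapping a Fluorinated Group for Carbamoyl: Expected Solubility

The source may report more compounds than this note shows. Statements on the series, on what has been measured and on what is new or still open speak of the compounds shown alone.

Measured so far:
Compound 1, `Cc1cc(NC(=O)Nc2ccccc2C(F)(F)F)c2ccccc2n1`, gives 3800 nM in a physicochemical assay for solubility, at pH 7.4; on this read-out higher numbers stand for higher solubility and lower numbers for lower solubility.
Compound 2, `Cc1cc(NC(=O)Nc2ccccc2F)c2ccccc2n1`, gives 3800 nM in this assay.
Compound 3, `Cc1cc(NC(=O)Nc2ccccc2OC(F)(F)F)c2ccccc2n1`, gives 4600 nM in this assay.

Compound 3 stands at the top of these three numbers, yet its gaps to compound 1 and compound 2 are within the scatter, so the three sit together. Compound 4, `Cc1cc(NC(=O)Nc2ccccc2C(N)=O)c2ccccc2n1`, differs from compound 3 by carbamoyl in place of trifluoromethoxy on an aromatic carbon. Within the data shown here, the steps of a 1.2-fold higher number from compound 1 to compound 3 (0.08 log units; within the scatter) and a 1.2-fold higher number from compound 2 to compound 3 (0.08 log units; within the scatter) swap one fluorinated group for another at the same place and stay within the scatter; none of the measured steps exchanges such a group for carbamoyl, so they give only a baseline. The step of a 2.0-fold higher number from compound 3 to compound 4 (0.29 log units; within the scatter) is expected to be upward but uncertain. Compound 4 is therefore estimated at 9000 nM, with a range from 3000 nM to 30000 nM.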

Compound 4, solubility: 200 nM
The estimate for compound 4 lay 45-fold (1.65 log units) above the measured number; measured number below the stated range.
By their numbers in this assay, from the lowest: compound 4; then compounds 1, 2 and 3 (each within the scatter of the next).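

On an aromatic carbon ortho to a large group, the three fluorinated groups gave matching numbers in this assay, but carbamoyl breaks that flat picture: the read-out shows a 23-fold lower number from compound 3 to compound 4 (1.36 log units; beyond the scatter) and also a 19-fold lower number from compound 2 to compound 4 (1.28 log units; beyond the scatter) and a 19-fold lower number from compound 1 to compound 4 (1.28 log units; beyond the scatter) with each step large. Among these compounds, the earlier compounds therefore showed only that this place tolerates exchange among fluorinated groups, not that any group there leaves the number unchanged. No measurement shown here accounts for this fall. Going by these compounds, whether a nitrile, an amine or a carboxylic acid at this place would stay with the fluorinated groups or fall with carbamoyl remains open.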